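Moving a hydroxyl group on a furan-bearing pyridine core

This account rests on a few compounds, and the source may have more. Where it says the series, first, only, none or still open, it means among the compounds named here.

Measured so far in a functional assay on HCT-15 cells (Homo sapiens) for cytotoxicity, read by CCK-8 assay; on this read-out higher numbers stand for weaker inhibition and lower numbers for stronger inhibition:
Compound 1 `Oc1ccc(-c2cc(-c3cccs3)cc(-c3ccc(O)cc3)n2)cc1` gives a limit of the assay, > 50000 nM.
Compound 2 `Oc1ccc(-c2cc(-c3ccsc3)cc(-c3ccc(O)cc3)n2)cc1` gives 1040 nM.
Compound 3 `Oc1ccc(-c2cc(-c3ccco3)cc(-c3cccc(O)c3)n2)cc1` gives 840 nM.

Compound 3 gives the lowest of the two numbers, though its gap to compound 2 lies within the usual scatter. Among the measured compounds shown here, the one measured step, an at least 48-fold lower number from compound 1 to compound 2 (1.68 log units; beyond the scatter), swaps one thiophene attachment for another and does not touch the hydroxyphenyl groups.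

Compound 4 `Oc1ccc(-c2cc(-c3ccco3)cc(-c3ccc(O)cc3)n2)cc1` differs from compound 3 only in 4-hydroxyphenyl in place of 3-hydroxyphenyl on an aromatic carbon. For the measured compounds named here, no measured step bears on this change, so no shift beyond the scatter is expected. Compound 4 is therefore estimated at 900 nM, with a range from 300 nM to 2700 nM, which is an expected step of a 1.1-fold higher number from compound 3 to compound 4 (0.03 log units; within the scatter).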

Compound 4, half-maximal inhibitory concentration: 14000 nM
The estimate for compound 4 lay 16-fold (1.19 log units) below the measured number; the whole stated range lies below it.
By their numbers in this assay, from the lowest: compounds 3 and 2 (each within the scatter of the next); then compound 4. At a limit, above all of these: compound 1.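

Keeping the same atoms and only moving the hydroxyl, from 3-hydroxyphenyl to 4-hydroxyphenyl, gives a 17-fold higher number from compound 3 to compound 4 (1.22 log units; beyond the scatter), so its place at this position matters. With the 4-hydroxyphenyl groups kept, the five-membered ring matters too: furan-2-yl in place of thiophen-3-yl gives a 13-fold higher number from compound 2 to compound 4 (1.13 log units; beyond the scatter), while furan-2-yl in place of thiophen-2-yl gives an at least 3.5-fold lower number from compound 1 to compound 4 (0.55 log units; beyond the scatter). That last step rests on a limit for compound 1: the limit of > 50000 nM in this assay, at which 1 of the 4 values shown sits.

Open, going by these compounds, is whether an amine or a methoxy group in place of the hydroxyl would keep the low number of compound 3, and whether 3-hydroxyphenyl would give a similar drop alongside either thiophene.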